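Working notes: three measured compounds and one estimate

A few compounds are considered here, and "the series" means these few. Any claim that something is new, unique, unknown or untested is made for them only; others in the source may bear on it.

Measured in a functional assay on HCC827 cells (Homo sapiens) for inhibition, read by MTT assay, with a stated time of 48 h, tested at 10 uM; a higher number here means more inhibition at the concentration tested (going by the name of the read-out), a lower number less inhibition:
compound 1 `Cc1ccc(Nc2cc(NC(=O)Nc3c(Cl)cccc3Cl)ncn2)cc1F` gives 85.3%
compound 2 `CCc1ccc(Nc2cc(NC(=O)Nc3cc(OC)cc(OC)c3)ncn2)cc1` gives 66.2%
compound 3 `COc1cc(NC(=O)Nc2cc(Nc3cc(C(F)(F)F)ccc3OC)ncn2)cc(OC)c1` gives 59.7%

Compound 2 stands second highest of the three numbers. Its nearest neighbour is compound 3, whose value lies within the usual scatter of the value of compound 2, so the two cannot be told apart on these data. Compound 1 lies furthest from compound 2, and that gap is beyond the scatter, so compound 1 shows more inhibition than compound 2 in this assay. Among the measured compounds shown here, no pair of the measured compounds differs in one place only, so no single-change step can be read from them.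

Compound 4 `CCc1cccc(Nc2cc(NC(=O)Nc3cc(OC)cc(OC)c3)ncn2)c1` has the same atoms as compound 2, joined differently:
3-ethylphenyl in place of 4-ethylphenyl on a nitrogen on an aromatic ring
The group that leaves is 4-ethylphenyl and the group that enters is 3-ethylphenyl, at a nitrogen on an aromatic ring whose other neighbours are aromatic carbon.

For the measured compounds named here, no measured step bears on a change of this kind, so the step is expected to be small, in no certain direction, and within the scatter: a number 4.2 percentage points lower from compound 2 to compound 4 (within the scatter) is the estimated step. Compound 4 is expected to give 62% in this assay, with an estimated range from 45% to 78%.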

Compound 4, a percentage reported as inhibition, at one concentration (the size of the read-out at that concentration, not a potency): 52.6%
The estimate for compound 4 lay 9.4 percentage points above the measured number; the measured number falls inside the stated range.
By their numbers in this assay, from the lowest: compounds 4, 3 and 2 (each within the scatter of the next, the first and the last beyond it); then compound 1.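

Working notes on the aryl group at the nitrogen: in this assay, replacing 4-ethylphenyl with 3-ethylphenyl gives a number 13.6 percentage points lower from compound 2 to compound 4 (beyond the scatter), the first single-change step available in this series. The two groups match in heavy atoms, ring type and hydrogen-bond counts, so at this nitrogen on an aromatic ring the placement of the ethyl group alone separates the pair at the one concentration tested. Nothing available explains why this placement changes the read-out.

As far as these compounds go, with only these two ethylphenyl groups compared at this nitrogen, it remains open how far the read-out depends on the ethyl group at all: an unsubstituted phenyl, or a propyl chain in place of the ethyl group, would address that directly. From the compounds shown here alone, it also remains open whether replacing 4-ethylphenyl with 3-ethylphenyl produces a similar step when the rest of the molecule is that of compound 1 or another member of the series, rather than the structure shared by this pair.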